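The source may report more compounds than this note shows. Statements on the series, on what has been measured and on what is new or still open speak of the compounds shown alone.

Of the compounds shown here, two have numbers so far. Compound 1 `C/C=C/[C@@H](CC(=O)O)NC(=O)[C@@H]1CCCN1S(=O)(=O)c1cc(Cl)cc(Cl)c1` gives 13 nM in an assay on RPMI-8866 cells for inhibition of integrin alpha-4/beta-1 (Homo sapiens); a lower number here means a stronger inhibitor, a higher number a weaker inhibitor. Compound 2 `O=C(O)C[C@@H](NC(=O)[C@@H]1CCN1S(=O)(=O)c1cc(Cl)cc(Cl)c1)c1ccc(OC2CC2)cc1` carries a cyclopropyloxy-substituted aryl group on the acid-bearing carbon in place of the alkene of compound 1 and a four-membered ring instead of the five-membered ring in the sulfonylated part of the core. In this assay compound 2 gives 0.31 nM; that is the lower of the two numbers, and the gap to compound 1 lies well beyond the scatter. Since the two compounds differ in more than one place, the gap cannot be assigned to either change.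

Compound 3 `O=C(O)C[C@@H](NC(=O)[C@@H]1CCN1S(=O)(=O)c1cc(Cl)cc(Cl)c1)c1ccc(Oc2ccccc2)cc1` is the next compound to be measured. It differs from compound 2 in one place only: phenyl in place of cyclopropyl on an oxygen on an aromatic ring. Going by the values given here, no step between measured compounds bears on this change, so the expectation rests on compound 2 alone. The step from compound 2 to compound 3 is expected to be small and within the scatter, a 1.0-fold lower number from compound 2 to compound 3 (0.01 log units; within the scatter), with no strong reason to expect a loss. For compound 3 the estimate in this assay is 0.3 nM, within a range of 0.08 nM to 1.2 nM.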

Compound 3, half-maximal inhibitory concentration: 3.1 nM
Estimate against measurement, compound 3: 10-fold (1.01 log units) below; the measured number lies above the stated range.
By their numbers in this assay, from the lowest: compound 2; then compound 3; then compound 1.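

Going by these compounds alone, on an oxygen on an aromatic ring, this position responds to the group it carries: in this assay, phenyl in place of cyclopropyl gives a 10-fold higher number from compound 2 to compound 3 (1.00 log units; beyond the scatter), the first step that can be read as a single change. The exchange replaces a three-membered non-aromatic ring of 3 heavy atoms with a six-membered aromatic ring of 6 heavy atoms, while the hydrogen-bond donor and acceptor counts and the net charge of the two groups stay the same, so the loss goes with a change in the ring alone. No measurement bears on why the number rises, and the cause of the step remains unassigned.

Within the data shown here, with only two groups at this position, ring size and aromatic character change together and cannot be separated, and a cyclohexyloxy group, which has a six-membered non-aromatic ring of carbon only, would pull them apart. On these data alone, whether a smaller group such as methoxy, or a phenoxy ring bearing an amine, would keep or lose the number also stays open, as do the separate contributions of the two differences between compound 1 and compound 2.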